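This account rests on a few compounds, and the source may have more. Where it says the series, first, only, none or still open, it means among the compounds named here.

Two compounds in the series have been run through a functional assay on cells (Panel NCI-60 (60 carcinoma cell lines), Homo sapiens) for inhibition, read by sulforhodamine B assay, with a stated time of 48 h; a lower number here means a stronger inhibitor of growth, a higher number a weaker inhibitor of growth. Compound 1 `N=C(N)c1ccc(-c2ccc(-c3cc(Cl)cc(Cl)c3)s2)s1` gives 4460 nM in this assay. Compound 2 `COc1ccc(-c2ccc(-c3ccc(C(=N)N)o3)o2)cc1` gives 5890 nM, the higher of the two numbers, though compound 1 lies within the scatter of it. Compound 3 `N=C(N)c1ccc(-c2ccc(-c3ccc(Cl)cc3)o2)o1` differs from compound 2 by chloro in place of methoxy on an aromatic carbon. Going by the values given here, no measured pair isolates this change, so the step from compound 2 to compound 3 is expected to be small, with no direction beyond the scatter. Compound 3 is therefore estimated at 5000 nM, between 1700 nM and 15000 nM, an expected step of a 1.2-fold lower number from compound 2 to compound 3 (0.07 log units; within the scatter).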

Compound 3, concentration for total growth inhibition: 3720 nM
Compound 3: middle estimate off by 1.3-fold (0.13 log units), on the high side, and the stated range covers the measured number.
By their numbers in this assay, from the lowest: compounds 3, 1 and 2 (each within the scatter of the next).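

In this assay, chloro in place of methoxy on an aromatic carbon, para to a large group, gives a 1.6-fold lower number from compound 2 to compound 3 (0.20 log units; within the scatter). Going by these compounds alone, this is the first pair that isolates one change, and it shows that this position accepts either group with no difference beyond the scatter. No independent data bear on this step.

As far as these compounds go, whether an amine or a carboxylic acid at this position would move the number beyond the scatter remains open. So does whether the same exchange would read alike on the core of compound 1.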